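Cytotoxicity on MRC5 Cells: Varying the Amino Acid Side Chain

The source may hold more compounds than are shown below. What is called first, only, known or untested is meant among the compounds shown, and "the series" means these compounds.

Measured so far:
compound 1, `CC1=CCC[C@H]2[C@](C)(CC3=CC(=O)C=C(N[C@@H](CC(C)C)C(=O)O)C3=O)[C@@H](C)CC[C@]12C`: 73400 nM
compound 2, `CC1=CCC[C@H]2[C@](C)(CC3=CC(=O)C=C(NCCC(=O)O)C3=O)[C@@H](C)CC[C@]12C`: 80800 nM

Both compounds share one core and differ only in the group carried on an amine nitrogen. In an ADME assay on MRC5 cells (Homo sapiens) for cytotoxicity, read by MTT assay, with a stated time of 72 h (on this read-out higher numbers stand for weaker inhibition and lower numbers for stronger inhibition), compound 1 gives 73400 nM. In this assay compound 2 gives 80800 nM, and the two numbers lie within the scatter of each other, so neither stands apart on the numbers shown: a 1.1-fold higher number from compound 1 to compound 2 (0.04 log units; within the scatter).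

Compound 3, `CC1=CCC[C@H]2[C@](C)(CC3=CC(=O)C=C(N[C@@H](C(=O)O)C(C)C)C3=O)[C@@H](C)CC[C@]12C`, has not yet been measured in this assay. It differs from compound 2 by 1-carboxy-2-methylpropyl in place of 2-carboxyethyl on an amine nitrogen. Among the measured compounds shown here, the only measured step that bears on this is the one from compound 1 to compound 2, where a 1-carboxy-3-methylbutyl group was exchanged for 2-carboxyethyl and the number hardly moved: a 1.1-fold higher number from compound 1 to compound 2 (0.04 log units; within the scatter). Compound 3 brings back a group of the same kind as in compound 1, a 1-carboxy-2-methylpropyl group. No step beyond the scatter is therefore expected, and the estimated step is a 1.1-fold lower number from compound 2 to compound 3 (0.03 log units; within the scatter). For compound 3 the expected value in this assay is 75000 nM, with a range from 40000 nM to 150000 nM.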

Compound 3, half-maximal inhibitory concentration: 85400 nM
For compound 3 the middle estimate is 1.1-fold (0.06 log units) below the measured one, within the range that was stated.
By their numbers in this assay, from the lowest: compounds 1, 2 and 3 (each within the scatter of the next).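

Placing the 1-carboxy-2-methylpropyl group on the amine nitrogen extends the comparison to a third group: in this assay, replacing 2-carboxyethyl gives a 1.1-fold higher number from compound 2 to compound 3 (0.02 log units; within the scatter), and replacing 1-carboxy-3-methylbutyl gives a 1.2-fold higher number from compound 1 to compound 3 (0.07 log units; within the scatter). Compounds 1, 2 and 3 therefore cannot be told apart on this read-out, even though the entering group has 7 heavy atoms against 5 in 2-carboxyethyl and brings a defined stereocentre. Nothing in the data shown offers an explanation for this close agreement.

From the compounds shown here alone, all three groups carry a carboxylic acid, so it remains open whether the same agreement would hold with an ester, an amide, or a simple alkyl chain with no acid on this nitrogen. Also open, going by these compounds, are a side chain ending in an amine, one carrying a phenyl ring, and the opposite arrangement at the stereocentre of the 1-carboxy-2-methylpropyl group.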